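The source may report more compounds than this note shows. Statements on the series, on what has been measured and on what is new or still open speak of the compounds shown alone.

Measured in an ADME assay on a cell-free system (plasma, Homo sapiens) for metabolic stability, read by LC-MS; on this read-out higher numbers stand for a longer-lived compound and lower numbers for a shorter-lived compound:
- Compound 1 `CCCOC(=O)c1cccc(C(=O)Nc2cccc(-c3cc(C(=O)Nc4ccncc4F)ccc3CN)c2)c1`: < 0.0834 h
- Compound 2 `CCCCOC(=O)c1cccc(NC(=O)c2cccc(-c3cc(C(=O)Nc4ccncc4F)ccc3CN)c2)c1`: < 0.0834 h

In this assay compound 2 stands at < 0.0834 h, which is a limit and not a number. Going by the values given here, both measured compounds sit at the limit of < 0.0834 h in this assay, at which 2 of the 2 values shown sit, so they offer no measured step to learn from.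

Compound 3 `NCc1ccc(C(=O)Nc2ccncc2F)cc1-c1cccc(C(=O)Nc2cccc(CC(=O)O)c2)c1` has carboxymethyl in place of butoxycarbonyl on an aromatic carbon. Compound 2, with < 0.0834 h, carries butoxycarbonyl, and compound 3 is expected to do better without it. The expected at least 95-fold higher number from compound 2 to compound 3 (1.98 log units; beyond the scatter) is large and points towards a longer-lived compound. For compound 3 the estimate is 8 h, with an expected range from 1 h to 40 h.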

Compound 3, half-life: > 2 h
Compound 3 ended at the assay's limit; the forecaster's own chance of this, stated with the estimate: 50%; the middle value lies beyond the limit too.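

In this assay, going by these compounds alone, replacing butoxycarbonyl with carboxymethyl on this aromatic carbon gives an at least 23-fold higher number from compound 2 to compound 3 (1.37 log units; beyond the scatter), the first measurable step in this set. As far as these compounds go, compound 3 reads > 2 h, which is a limit, and compound 2 also sits at a limit, so the true size of the step remains unknown. Even so, the group at this one position clearly separates a short-lived compound from a much longer-lived one.

From the compounds shown here alone, how long compound 3 actually lasts remains open. So does whether another group at this carbon, such as an amine or a hydroxymethyl, would give a similar rise.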